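A few compounds are considered here, and "the series" means these few. Any claim that something is new, unique, unknown or untested is made for them only; others in the source may bear on it.

Measured so far in an ADME assay on HepG2 cells (Homo sapiens) for cytotoxicity, read by luminescence, with a stated time of 72 h; on this read-out higher numbers stand for an effect only at larger amounts of compound and lower numbers for an effect already at smaller amounts:
- compound 1, `CCOC(=O)c1c(-c2cc(F)cc(OC)c2)[nH]c2cc(OC)ccc2c1=O`, gives > 21500 nM, a limit of the assay and not a number.
- compound 2, `CCOC(=O)c1c(-c2cccc(-c3ccccc3)c2)[nH]c2cc(OC)ccc2c1=O`, gives > 21500 nM, likewise a limit.
- compound 3, `CCOC(=O)c1c(-c2cccc(F)c2)[nH]c2cc(OC)ccc2c1=O`, gives > 21500 nM, again a limit.

All three compounds share a core and differ in the ring hanging from it. Compound 2 and compound 3 differ by phenyl in place of fluoro on an aromatic carbon, and the step that the two limits leave unreadable from compound 2 to compound 3 cannot be read because both values are limits. Compound 3 and compound 1 differ by methoxy in place of hydrogen on an aromatic carbon, and here too the step that the two limits leave unreadable from compound 3 to compound 1 is hidden behind the limits, as the limit of > 21500 nM in this assay, at which 3 of the 3 values shown sit, shows.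

Compound 4, `CCOC(=O)c1c(-c2cccc(-c3ccccc3)c2)[nH]c2cc(OC)c(OC)cc2c1=O`, has not been measured in this assay. It differs from compound 2 by methoxy in place of hydrogen on an aromatic carbon. This is the same kind of change as from compound 3 to compound 1, but not the same: in compound 4 the methoxy enters a ring that is part of a fused or bridged system of two rings, ortho to a methoxy group, meta to a fused ring and para to a fused ring, whereas in compound 1 it enters a ring that is meta to a fluoro group and meta to a large group.

With every value shown sitting at the limit named in the limit of > 21500 nM in this assay, at which 3 of the 3 values shown sit, the step from compound 2 to compound 4 is expected to be about a step that the limit leaves unreadable from compound 2 to compound 4. Compound 4 is therefore expected to give roughly 30000 nM in this assay, most likely again reported only as a limit, somewhere between 21500 nM and 70000 nM.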

Compound 4, half-maximal effective concentration: > 21500 nM
Compound 4: no number, only a limit; the forecaster's own chance of this, stated with the estimate: 85%; the middle value does not contradict the limit.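

In this assay, going by these compounds alone, compound 2 and compound 4 both give only a limit and not a number, so the effect of the added methoxy cannot be read and no new step follows: the limit of > 21500 nM in this assay, at which 4 of the 4 values shown sit. The compounds shown leave open at what concentration any of the four would have an effect in this assay, and whether the changes among them alter that concentration at all.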